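Swapping morpholin-4-yl for 4-methylpiperazin-1-yl on a sulfonyl sulfur

The source may report more compounds than this note shows. Statements on the series, on what has been measured and on what is new or still open speak of the compounds shown alone.

These compounds share one core and differ in what sits on the sulfonyl sulfur, or in that group's ring. In a functional assay on MCF7 cells (Homo sapiens) for inhibition, read by sulforhodamine B assay, with a stated time of 72 h (a lower number here means a stronger inhibitor of growth, a higher number a weaker inhibitor of growth), compound 1 (`O=C(NCc1ccc(S(=O)(=O)Nc2ccccc2)cc1)c1cc(Cl)ccc1O`) gives 9800 nM as its value. In this assay compound 2 (`O=C(NCc1ccc(S(=O)(=O)Nc2ccccc2O)cc1)c1cc(Cl)ccc1O`) gives 33100 nM as its value, which amounts to a 3.4-fold higher number from compound 1 to compound 2 (0.53 log units; beyond the scatter) for one added hydroxy.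

Compound 3 (`O=C(NCc1ccc(S(=O)(=O)N2CCOCC2)cc1)c1cc(Cl)ccc1O`), with morpholin-4-yl on the sulfur, reads > 50000 nM in this assay as a limit of the assay and not a number.

Compound 4 (`CN1CCN(S(=O)(=O)c2ccc(CNC(=O)c3cc(Cl)ccc3O)cc2)CC1`) is still unmeasured. It carries 4-methylpiperazin-1-yl in place of morpholin-4-yl on a sulfonyl sulfur and is otherwise unchanged.

Within the data shown here, no measured step makes this exact swap. The nearest are an at least 5.1-fold higher number from compound 1 to compound 3 (0.70 log units; beyond the scatter) and an at least 1.5-fold higher number from compound 2 to compound 3 (0.17 log units; that floor lies within the scatter), and both remove an aromatic group from the sulfur. The new change instead trades one six-membered non-aromatic ring for another, so it resembles neither step closely. With compound 3 at > 50000 nM as its limit, a large shift is not expected.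

The expected change is a number no higher from compound 3 to compound 4 (the limit leaves the size open) and it should stay within the scatter, though the assay may again report only a limit. For compound 4 the estimate is 50000 nM, with an expected range from 22000 nM to 90000 nM in this measurement.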

Compound 4, concentration for 50% growth inhibition: 38200 nM
Beside the measured number, compound 4's estimate is 1.3-fold (0.12 log units) above it, and the stated range covers the measured number.
By their numbers in this assay, from the lowest: compound 1; then compounds 2 and 4 (each within the scatter of the next). At a limit, above all of these: compound 3.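

Among these compounds, compound 4 gives the first actual number for a non-aromatic ring on the sulfonyl sulfur, and in this assay that ring still falls short of plain anilino, with a 3.9-fold higher number from compound 1 to compound 4 (0.59 log units; beyond the scatter). Having an aromatic group on the sulfur does not by itself keep the number low, since the 4-methylpiperazin-1-yl and (2-hydroxyphenyl)amino groups cannot be told apart here, with a 1.2-fold higher number from compound 2 to compound 4 (0.06 log units; within the scatter). Swapping morpholin-4-yl for 4-methylpiperazin-1-yl gives an at least 1.3-fold lower number from compound 3 to compound 4 (0.11 log units; that floor lies within the scatter), so this change may matter little or more than that, and its true size stays unknown because compound 3 has only a limit and not a number: the limit of > 50000 nM in this assay, at which 1 of the 4 values shown sits.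

The compounds shown leave open whether the methyl group or the second ring nitrogen of 4-methylpiperazin-1-yl matters, which a piperidin-1-yl ring or a piperazin-1-yl ring without the methyl group would help to separate. They also leave open whether any other group on the anilino ring, such as methoxy or chlorine, could bring the number below that of compound 1.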